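The source may report more compounds than this note shows. Statements on the series, on what has been measured and on what is new or still open speak of the compounds shown alone.

Three compounds have been measured in a functional assay on K562 cells (Homo sapiens) for antiproliferative activity, read by MTT assay, with a stated time of 48 h; on this read-out higher numbers stand for weaker inhibition of growth and lower numbers for stronger inhibition of growth:

Compound 1, `CCOc1cc(NC(=O)CCCCC(=O)Nc2cc(-c3ccc(C)s3)ccc2N)cc2c1OCC([N+](=O)[O-])=C2`, gives 2940 nM.
Compound 2, `CCOc1cc(NC(=O)CCCCC(=O)Nc2ccccc2N)cc2c1OCC([N+](=O)[O-])=C2`, gives 3680 nM.
Compound 3, `CCOc1cc(NC(=O)CCCCCC(=O)Nc2cc(-c3ccc(C)s3)ccc2N)cc2c1OCC([N+](=O)[O-])=C2`, gives 2920 nM.

Compound 1 and compound 2 share a core and differ in one place: hydrogen in place of 5-methylthiophen-2-yl on an aromatic carbon. The step that accompanies this change is a 1.3-fold higher number from compound 1 to compound 2 (0.10 log units; within the scatter), so the two values sit within the scatter of each other and neither compound can be said to inhibit growth more strongly than the other.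

Compound 3 carries the same 5-methylthiophen-2-yl group as compound 1 but on a different core; the difference between the two cores is not broken down here. Its value and that of compound 1 lie within the scatter of one another, as do its value and that of compound 2.

Compound 4, `CCOc1cc(NC(=O)CCCCCC(=O)Nc2ccccc2N)cc2c1OCC([N+](=O)[O-])=C2`, has not yet been measured. It stands to compound 3 as compound 2 stands to compound 1: hydrogen in place of 5-methylthiophen-2-yl on an aromatic carbon. The surroundings of the place are described in the same words for both pairs, so this is the same change, made for the second time among these compounds.

Compound 4 is expected to show a 1.3-fold higher number from compound 3 to compound 4 (0.10 log units; within the scatter) in this assay. For the measured compounds named here, this expectation rests on the single measured occurrence of the change, a 1.3-fold higher number from compound 1 to compound 2 (0.10 log units; within the scatter), a step that stayed within the scatter; there is no second measured pair to test it against. On that basis compound 4 is estimated at 3700 nM, with a range expected from 2000 nM to 6800 nM.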

Compound 4, concentration for 50% growth inhibition: 3960 nM
Beside the measured number, compound 4's estimate is 1.1-fold (0.03 log units) below it; measured number inside the range.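

In this assay, putting hydrogen in place of 5-methylthiophen-2-yl on the core of compound 3 gives a 1.4-fold higher number from compound 3 to compound 4 (0.13 log units; within the scatter), and the same change has now been read on two cores, with steps that agree: the same change on two cores in this assay, a 1.3-fold higher number (0.10 log units; within the scatter) from compound 1 to compound 2 and a 1.4-fold higher number (0.13 log units; within the scatter) from compound 3 to compound 4, 1.1-fold (0.03 log units) apart, within the scatter of two such steps. The exchange of (2-aminophenyl)carbamoyl for ((2-aminophenyl)carbamoyl)methyl on the saturated chain, seen in a 1.1-fold higher number from compound 2 to compound 4 (0.03 log units; within the scatter), also stays within the scatter, so the two cores give no readable difference when neither carries the thiophene group. This shows that the change carried over from one core to the other as a step within the scatter both times, but it does not show that 5-methylthiophen-2-yl adds to or takes away from growth inhibition on either core, and two pairs on cores this close say nothing about how the change would behave on a more distant one.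

The compounds shown leave open whether another group at this place on the aromatic ring, such as phenyl, chlorine or an amine, or a shorter or longer chain, would move the number beyond the scatter. They also leave open whether the agreement between the two steps would hold in any read-out other than this assay.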